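Boronic acid group swapped for a ring-bearing boron group

The source may report more compounds than this note shows. Statements on the series, on what has been measured and on what is new or still open speak of the compounds shown alone.

Among the measured compounds shown here, in a functional assay on PANC-1 cells (Homo sapiens) for cytotoxicity, read by MTT assay, with a stated time of 48 h (on this read-out higher numbers stand for weaker inhibition and lower numbers for stronger inhibition), compound 1 `O=C(NCCCOc1no[n+]([O-])c1S(=O)(=O)c1ccccc1)c1ccc2cccc(OCc3ccc(B(O)O)cc3)c2n1` gives 10500 nM and compound 2 `O=C(NCCCOc1no[n+]([O-])c1S(=O)(=O)c1ccccc1)c1ccc2cccc(O)c2n1` gives 7540 nM as the only two numbers so far. These two numbers lie within the scatter of each other, so neither compound stands apart.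

Compound 3 `CC1(C)OB(c2ccc(COc3cccc4ccc(C(=O)NCCCOc5no[n+]([O-])c5S(=O)(=O)c5ccccc5)nc34)cc2)OC1(C)C` has not been measured. The difference a group of 9 heavy atoms (6 carbon, 1 boron, 2 oxygen; one five-membered non-aromatic ring with 3 hetero atoms) in place of a group of 3 heavy atoms (1 boron, 2 oxygen; no ring), on an aromatic carbon sits on an aromatic carbon para to a large group.

For the measured compounds named here, one measured step bears on this change. It is a 1.4-fold lower number from compound 1 to compound 2 (0.14 log units; within the scatter) and it takes away the whole group of 10 heavy atoms on the oxygen. Even that larger removal stays within the scatter, so the smaller change at the end of the same group is expected to give no step beyond the scatter in this assay and no clear direction. Going by the values given here, no measured compound carries the five-membered non-aromatic ring, so this expectation rests on a single step.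

The expected step is a 1.1-fold lower number from compound 1 to compound 3 (0.04 log units; within the scatter) and lies within the scatter. For compound 3 the estimated value is 9500 nM with an expected range from 4500 nM to 20000 nM in this series.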

Compound 3, half-maximal inhibitory concentration: 17100 nM
Compound 3: the middle estimate sits 1.8-fold (0.26 log units) below what was measured; the range from low to high includes it.
By their numbers in this assay, from the lowest: compounds 2, 1 and 3 (each within the scatter of the next, the first and the last beyond it).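

In this assay the group of 9 heavy atoms with its five-membered non-aromatic ring, in place of the group of 3 heavy atoms on this aromatic carbon para to a large group, gives a 1.6-fold higher number from compound 1 to compound 3 (0.21 log units; within the scatter) in the series, so this position accepts the larger boron group, with 0 hydrogen-bond donors instead of 2, without a step beyond the scatter. The series now also holds its first gap beyond the scatter, since compound 2 gives 7540 nM in the same cells and compound 3 gives 17100 nM there, while compound 1 stays within the scatter of each. Nothing available explains these numbers.

The compounds shown leave open whether the boron atom has any bearing on the number at all, and a carboxylic acid or an amine in place of the boron group on the same aromatic carbon would test that. They also leave open whether a longer chain on the oxygen of the shared core would move the number beyond the scatter of compound 1 in this cell line.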